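The source may hold more compounds than are shown below. What is called first, only, known or untested is meant among the compounds shown, and "the series" means these compounds.

Compound 1 `NC(=O)c1ccc(-c2cccnc2)cc1Cl`: 11000 nM
Compound 2 `Cc1ncccc1-c1ccc(C(N)=O)cc1`: 170000 nM

In an assay on cells for inhibition of MAP kinase-interacting serine/threonine-protein kinase 1 (Homo sapiens), read by mobility shift assay, with stated times of 10 min and 60 min, in the presence of a further agent that is not named here (a higher number here means a weaker inhibitor, a lower number a stronger inhibitor), compound 1 gives 11000 nM, the lowest of the two numbers shown; compound 2 gives 170000 nM, a gap that lies beyond the scatter. Compound 3 `CC(C)Oc1cc(-c2cccnc2)ccc1C(N)=O` has not been measured. It differs from compound 1 in one place isopropoxy in place of chloro on an aromatic carbon. Nothing measured here tells how such a change plays out, so the step from compound 1 to compound 3 is expected to be small, a 1.4-fold lower number from compound 1 to compound 3 (0.14 log units; within the scatter), likely within the scatter. Compound 3 is therefore estimated at 8000 nM, with a range from 2000 nM to 30000 nM.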

Compound 3, half-maximal inhibitory concentration: 880 nM
Estimate against measurement, compound 3: 9.1-fold (0.96 log units) above, and the stated range ends above it.
By their numbers in this assay, from the lowest: compound 3; then compound 1; then compound 2.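

The position ortho to a carbamoyl group proves responsive to what it carries: in this assay, isopropoxy in place of chloro gives a 13-fold lower number from compound 1 to compound 3 (1.10 log units; beyond the scatter). This position therefore accepts a larger group that brings in an oxygen, and the number falls well beyond the scatter. Nothing measured here bears on why the step is so large. As far as these compounds go, whether methoxy, a longer ether chain or an amine at this position would do as well or better stays open. So does whether the same change would carry over to the core of compound 2.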